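A few compounds are considered here, and "the series" means these few. Any claim that something is new, unique, unknown or untested is made for them only; others in the source may bear on it.

Measured so far in an ADME assay on microsomes (Homo sapiens) for metabolic stability; a lower number here means that the compound disappears faster, a higher number that the compound lasts longer:
- compound 1 `CC(C)(C)C(=O)N1CCSC1c1ccccc1`: 0.3 h
- compound 2 `N#Cc1nccc(N2CCC(C(=O)N3N=CC[C@H]3c3cc(F)cc(F)c3)CC2)n1`: 2.1 h

Of these two, compound 2 has the higher half-life, and the gap to compound 1 lies beyond the usual scatter. Compound 3 `N#Cc1cc(N2CCC(C(=O)N3N=CC[C@H]3c3cc(F)cc(F)c3)CC2)ncn1` has the same atoms as compound 2, joined differently: a group of 8 heavy atoms (5 carbon, 3 nitrogen; one six-membered aromatic ring with 2 hetero atoms) in place of a group of 8 heavy atoms (5 carbon, 3 nitrogen; one six-membered aromatic ring with 2 hetero atoms), on an amine nitrogen in a ring. Among the measured compounds shown here, no measured pair shows a change of this kind. For the measured compounds named here, the only anchor is compound 2 at 2.1 h, so no step beyond the scatter is expected in this assay, in either direction. The expected change is a 1.2-fold lower number from compound 2 to compound 3 (0.07 log units; within the scatter). For compound 3 the estimated half-life is 1.8 h, with an expected range of 0.7 h to 4.5 h.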

Compound 3, half-life: 3.3 h
Compound 3: middle estimate off by 1.8-fold (0.26 log units), on the low side; the range from low to high includes it.
By their numbers in this assay, from the lowest: compound 1; then compounds 2 and 3 (each within the scatter of the next).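

In this assay, rearranging the same atoms of the 2-cyanopyrimidin-4-yl group, on an amine nitrogen in a ring, gives a step (a 1.6-fold higher number from compound 2 to compound 3 (0.20 log units; within the scatter)) that cannot be told apart from repeat variation. At this position, the half-life therefore does not separate these two isomeric groups, each with a six-membered aromatic ring with 2 hetero atoms. Nothing on hand bears on the reason for this result.

Still open, as far as these compounds go, is whether a group other than the nitrile, such as a methoxy group or a primary amide, would hold the half-life on this ring. From the compounds shown here alone, a phenyl ring in this place also remains untested against these two groups.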